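Returning to a biaryl on the shared core

The source may report more compounds than this note shows. Statements on the series, on what has been measured and on what is new or still open speak of the compounds shown alone.

Of the compounds shown here, two with a shared core have been measured. Compound 1, `COC(=O)/C=C/c1cccc(N(Cc2ccc(-c3cccc(OC)c3)cc2)C(=O)NC(C)C)c1`, gives 1370 nM in an assay on isolated protein with Bile acid receptor (Homo sapiens) as the target; on this read-out higher numbers stand for an effect only at larger amounts of compound and lower numbers for an effect already at smaller amounts. Among the compounds with values here, compound 2, `COC(=O)/C=C/c1cccc(N(Cc2ccc(/C=C/C(=O)OC(C)(C)C)cc2)C(=O)NC(C)C)c1`, gives 212 nM in this assay, the lowest of the two numbers; its nearest neighbour is compound 1, and the only measured step, a 6.5-fold lower number from compound 1 to compound 2 (0.81 log units; beyond the scatter), shows a modest change beyond the scatter when a 2-(tert-butoxycarbonyl)ethenyl group takes the place of a 3-methoxyphenyl group.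

Compound 3, `COC(=O)/C=C/c1cccc(N(Cc2ccc(-c3cccc(C)c3)cc2)C(=O)NC(C)C)c1`, has not yet been measured. It differs from compound 2 in one place: 3-methylphenyl in place of 2-(tert-butoxycarbonyl)ethenyl on an aromatic carbon, on an aromatic carbon of a six-membered aromatic ring of carbon only, para to a large group. Within the data shown here, this change largely undoes the one measured step, since a methyl-bearing phenyl ring returns where compound 1 carried a methoxy-bearing one. Among the measured compounds shown here, the step from compound 1 to compound 2 is therefore the only guide, and it points toward a higher number for compound 3.

Compound 3 is expected to come out near the number of compound 1, with the estimated step of a 5.7-fold higher number from compound 2 to compound 3 (0.75 log units; beyond the scatter), giving an estimate of 1200 nM with a range from 400 nM to 3600 nM.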

Compound 3, half-maximal effective concentration: 1330 nM
For compound 3 the middle estimate is 1.1-fold (0.04 log units) below the measured one; the range from low to high includes it.
By their numbers in this assay, from the lowest: compound 2; then compounds 3 and 1 (each within the scatter of the next).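

At this position of the shared core, a second aryl group now gives the same picture as the first: in this assay, 3-methylphenyl in place of 2-(tert-butoxycarbonyl)ethenyl gives a 6.3-fold higher number from compound 2 to compound 3 (0.80 log units; beyond the scatter) and so stands close in size to the earlier step. The exact substituent on the outer phenyl ring makes no visible difference in this pair, since methyl in place of methoxy gives a 1.0-fold lower number from compound 1 to compound 3 (0.01 log units; within the scatter) and leaves the two numbers indistinguishable. Among these three compounds, then, the two aryl-bearing compounds sit together and compound 2 alone carries the lower number, although nothing available here accounts for that gap.

Going by these compounds, what remains open is which part of the 2-(tert-butoxycarbonyl)ethenyl group goes with the lower number, the double bond or the tert-butyl ester. A carboxylic acid in place of that ester, or a saturated two-carbon chain in place of the ethenyl link, would separate those two parts, and an amine on the outer phenyl ring would test whether that ring tolerates more than methyl and methoxy.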